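The compounds below may be only part of what the source reports. "The series", "measured", "known", "first", "only" and "open" are said of these compounds alone.

In an ADME assay on T29 cells (Homo sapiens) for cytotoxicity, read by sulforhodamine B assay, with a stated time of 3 days (a higher number here means a weaker inhibitor, a lower number a stronger inhibitor), compound 1 `O=Cc1cn(Cc2ccc(Cl)cc2)c2ccc(F)cc12` gives > 31600 nM, which is a limit of the assay and not a number. Compound 2 `OCc1cn(Cc2ccc(Br)cc2)c2ccccc12` gives > 31600 nM, again a limit. Compound 3 `OCc1cn(Cc2cccc(C(F)(F)F)c2)c2ccccc12` gives > 31600 nM, also a limit. The whole set therefore comes down to one observation: the limit of > 31600 nM in this assay, at which 3 of the 3 values shown sit. Compound 2 has no measured number, only this limit, and it shares that position with both of the other tested compounds. Within the data shown here, no step between measured compounds is available to serve as a guide.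

Compound 4 `O=[N+]([O-])c1ccc(Cn2cc(CO)c3ccccc32)cc1` has not yet been measured. It departs from compound 2 at one place: nitro in place of bromo on an aromatic carbon. This puts nitro in place of bromo on an aromatic carbon, para to a large group. The expectation rests on compound 2 alone as the closest neighbour, whose result of > 31600 nM is a limit. No change beyond the scatter is expected in this assay, in either direction, so the estimated step that the limit leaves unreadable from compound 2 to compound 4 should be read as no real shift. A further limit is the most likely report. For compound 4 the estimate is 40000 nM, with an expected range of 12000 nM to 100000 nM.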

Compound 4, half-maximal inhibitory concentration: > 31600 nM
Compound 4: only a limit was reported; the forecaster's own chance of this, stated with the estimate: 75%; the middle value lies beyond the limit too.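

Compound 4 gives > 31600 nM in this assay and this is a limit of the assay, not a number. Among these compounds, compound 2 also carries only a limit, so no step between compound 2 and compound 4 can be read. The compounds shown leave open whether this assay would return an actual number for any change to the shared core.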